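Bromophenyl thioether after the methyl analogue lost activity

The source may report more compounds than this note shows. Statements on the series, on what has been measured and on what is new or still open speak of the compounds shown alone.

Measured compounds:
compound 1, `C#CCNC1CCc2c(SCc3cccc(F)c3)cccc21`, 1480 nM
compound 2, `C#CCNC1CCc2c(SCc3cccc(C)c3)cccc21`, > 100000 nM

Compound 1 and compound 2 share the same core and differ only in the substituent on the pendant aromatic ring. In an assay on isolated protein for inhibition of Amine oxidase [flavin-containing] B (Homo sapiens) (a higher number here means a weaker inhibitor, a lower number a stronger inhibitor), compound 1 gives 1480 nM. For compound 2 the result is only a limit of the assay, > 100000 nM. As far as these compounds go, compound 2 therefore stands at the limit of > 100000 nM in this assay, at which 1 of the 2 values shown sits, and its true position beyond that limit is unknown. Among the compounds with values here, the single measured step, an at least 67-fold higher number from compound 1 to compound 2 (1.82 log units; beyond the scatter), is the only guide available.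

Compound 3, `C#CCNC1CCc2c(SCc3ccc(Br)cc3)cccc21`, differs from compound 2 by 4-bromophenyl in place of 3-methylphenyl on a saturated chain carbon bound to a sulfur. This change removes the methyl group that accompanied the large loss seen in an at least 67-fold higher number from compound 1 to compound 2 (1.82 log units; beyond the scatter) and brings back a halogen, though bromine rather than fluorine, so the step of an at least 16-fold lower number from compound 2 to compound 3 (1.22 log units; beyond the scatter) is expected to go toward a lower number, in the direction of compound 1, but its size cannot be fixed from one comparison. Compound 3 is therefore estimated at 6000 nM in this assay, with a range from 600 nM to 60000 nM.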

Compound 3, half-maximal inhibitory concentration: 1310 nM
The estimate for compound 3 lay 4.6-fold (0.66 log units) above the measured number, and the stated range covers the measured number.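

In this assay, the 4-bromophenyl on a saturated chain carbon bound to a sulfur recovers what the 3-methylphenyl had lost, with an at least 76-fold lower number from compound 2 to compound 3 (1.88 log units; beyond the scatter), which shows that the large loss seen with compound 2 does not extend to every change at this position. Set against the 3-fluorophenyl, the 4-bromophenyl gives no difference that can be told apart, with a 1.1-fold lower number from compound 1 to compound 3 (0.05 log units; within the scatter), so this position accepts both of these halogen-bearing rings about equally, and only the 3-methylphenyl stands apart among the three compounds. Compound 2 gives only a limit of the assay, so the step towards compound 3 has no fixed size: the limit of > 100000 nM in this assay, at which 1 of the 3 values shown sits.

The step between the 3-fluorophenyl and the 4-bromophenyl changes both the halogen and the name's ring number at once, so the compounds shown cannot separate the part played by the halogen from the part played by where it sits on the ring. As far as these compounds go, it also remains open how this position would respond to an unsubstituted phenyl, a chlorine or a methoxy group on the pendant ring.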